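Moving Two Chlorines Around the Benzamide Ring

A few compounds are considered here, and "the series" means these few. Any claim that something is new, unique, unknown or untested is made for them only; others in the source may bear on it.

Measured compounds in a functional assay on Vero cells (Chlorocebus sabaeus) for inhibition; a lower number here means a stronger inhibitor, a higher number a weaker inhibitor:
compound 1 `COc1cc(/C=C/C(=O)c2cccc(NC(=O)c3ccccc3)c2)ccc1O`, 3.47 ug/mL
compound 2 `COc1cc(/C=C/C(=O)c2cccc(NC(=O)c3cc(Cl)cc(Cl)c3)c2)ccc1O`, > 50 ug/mL
compound 3 `COC(=O)C(=O)Nc1cccc(C(=O)/C=C/c2ccc(O)c(OC)c2)c1`, 3.55 ug/mL

Compound 2 stands apart from the other two. Its reading is not a number but a limit of the assay, the one at the limit of > 50 ug/mL in this assay, at which 1 of the 3 values shown sits. Compound 1 and compound 3 both give firm numbers; the step of a 1.0-fold higher number from compound 1 to compound 3 (0.01 log units; within the scatter) lies within the scatter, so the two cannot be told apart. Against them, an at least 14-fold higher number from compound 1 to compound 2 (1.15 log units; beyond the scatter) and an at least 14-fold lower number from compound 2 to compound 3 (1.14 log units; beyond the scatter) are both large, so the 3,5-dichlorophenyl group has, among these three, the weakest showing.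

Compound 4 `COc1cc(/C=C/C(=O)c2cccc(NC(=O)c3c(Cl)cccc3Cl)c2)ccc1O` has not been measured. It carries the same atoms as compound 2, joined differently: 2,6-dichlorophenyl in place of 3,5-dichlorophenyl on a carbonyl carbon. Among the compounds with values here, no measured step moves chlorines from one set of ring positions to another, so none bears directly on this change. The nearest guide is compound 2 itself, and it offers only a limit, so the expected step from compound 2 cannot be drawn from the numbers.

Compound 4 is therefore estimated at 30 ug/mL, with a range from 8 ug/mL to 50 ug/mL. That estimate means an expected step of an at least 1.6-fold lower number from compound 2 to compound 4 (0.22 log units; that floor lies within the scatter), with a real chance that compound 4 again returns only a limit.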

Compound 4, half-maximal inhibitory concentration: 2.48 ug/mL
Estimate against measurement, compound 4: 12-fold (1.08 log units) above; the measured number lies below the stated range.
By their numbers in this assay, from the lowest: compounds 4, 1 and 3 (each within the scatter of the next). At a limit, above all of these: compound 2.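

In this assay the same atoms give very different results depending on how the chlorines are arranged: an at least 20-fold lower number from compound 2 to compound 4 (1.30 log units; beyond the scatter) is a large step, although the 3,5-dichlorophenyl and 2,6-dichlorophenyl groups differ in nothing the counts can show. Two chlorines on this ring are therefore no penalty in themselves, for a 1.4-fold lower number from compound 1 to compound 4 (0.15 log units; within the scatter) and a 1.4-fold lower number from compound 3 to compound 4 (0.16 log units; within the scatter) both lie within the scatter, which places the 2,6-dichlorophenyl group level with phenyl and methoxycarbonyl on this carbonyl carbon and leaves only the 3,5-dichlorophenyl group out of line. The reading for compound 2 is a limit of the assay and not a number, so the large step is a floor and its true size stays unknown: the limit of > 50 ug/mL in this assay, at which 1 of the 4 values shown sits.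

These compounds do not say what lies behind the gap between the two dichlorophenyl groups, nor whether a phenyl ring carrying a single chlorine would fall with compound 2 or with compound 4. From the compounds shown here alone, it also remains open how a methyl, a methoxy group, an amine or a carboxylic acid on this ring would read in this assay on this same core.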